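Removing the methylsulfonyl group from compound 3

The source may report more compounds than this note shows. Statements on the series, on what has been measured and on what is new or still open speak of the compounds shown alone.

In a functional assay on HeLa cells (Homo sapiens) for inhibition, read by MTT assay, with a stated time of 24 h, tested at 10 uM (on this read-out higher numbers stand for more inhibition of growth at the one concentration tested and lower numbers for less inhibition of growth), compound 1 `CS(=O)(=O)c1ccc(-c2cnc3[nH]cc(-c4nnc(-c5ccncc5)o4)c(=O)c3c2)cc1` gives 18.4%, compound 2 `CS(=O)(=O)c1ccc(-c2cnc3[nH]cc(-c4nnc(-c5ccc(F)cc5)o4)c(=O)c3c2)cc1` gives 15.7% and compound 3 `CS(=O)(=O)c1ccc(-c2cnc3[nH]cc(-c4nnc(-c5ccc(Cl)cc5)o4)c(=O)c3c2)cc1` gives 1.64%. Compound 3 stands lowest of the three; the step of a number 16.8 percentage points lower from compound 1 to compound 3 (beyond the scatter) and the step of a number 14.1 percentage points lower from compound 2 to compound 3 (beyond the scatter) both run beyond the scatter, whereas the step of a number 2.7 percentage points lower from compound 1 to compound 2 (within the scatter) does not.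

Compound 4 `O=c1c(-c2nnc(-c3ccc(Cl)cc3)o2)c[nH]c2ncc(-c3ccccc3)cc12` differs from compound 3 in one place: hydrogen in place of methylsulfonyl on an aromatic carbon. Going by the values given here, none of the measured steps touches this part of the molecule; all three vary only the ring attached to the oxadiazole while the 4-(methylsulfonyl)phenyl group is kept throughout. Among the compounds with values here, there is therefore no measured step that bears on this change, and no direction can be read from the data. In the absence of any guide, the step of a number 3.4 percentage points higher from compound 3 to compound 4 (within the scatter) is expected to stay within the scatter, with the uncertainty widened accordingly. Compound 4 is thus estimated at 5%, in a range from -8% to 22%.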

Compound 4, percent growth inhibition at one concentration: 31.3%
Beside the measured number, compound 4's estimate is 26.3 percentage points below it, and the stated range ends below it.
By their numbers in this assay, from the lowest: compound 3; then compounds 2 and 1 (each within the scatter of the next); then compound 4.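

Going by these compounds alone, until now the 4-(methylsulfonyl)phenyl group had been held constant, so this is the first read on that position. In this assay the change from 4-(methylsulfonyl)phenyl to phenyl gives a number 29.7 percentage points higher from compound 3 to compound 4 (beyond the scatter) and so moves the number, which shows that the group on this ring is not a silent part of the molecule and that, with 4-chlorophenyl on the oxadiazole, growth inhibition does not depend on keeping the methylsulfonyl group. Nothing available explains why this step goes in this direction.

As far as these compounds go, whether removing the methylsulfonyl group gives a similar step with pyridin-4-yl or 4-fluorophenyl on the oxadiazole stays open, since this change is seen in one pair only. From the compounds shown here alone, it is also open how an amine, a methoxy group or a carboxylic acid would read at this same place on the ring.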